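Amide substituent changes and kinetic solubility in one series

The source may hold more compounds than are shown below. What is called first, only, known or untested is meant among the compounds shown, and "the series" means these compounds.

Compound 1 `C=CC(=O)Nc1cccc(-c2nc3ccccc3s2)c1` sits lowest of the three measured compounds in a physicochemical assay for solubility, in phosphate buffer, measured as kinetic solubility, with a stated time of 18 h, at pH 7.4 (a higher number here means a more soluble compound, a lower number a less soluble compound), at 180 nM. Compound 3 `CC(Cl)C(=O)Nc1cccc(-c2nc3ccccc3s2)c1` gives 830 nM, the step being a 4.6-fold higher number from compound 1 to compound 3 (0.66 log units; beyond the scatter); compound 2 `CN(C)CCC(=O)Nc1cccc(-c2nc3ccccc3s2)c1` gives 56000 nM, with a 310-fold higher number from compound 1 to compound 2 (2.49 log units; beyond the scatter). Compound 4 `O=C(Nc1cccc(-c2nc3ccccc3s2)c1)c1cnccc1Cl` differs from compound 1 by 4-chloropyridin-3-yl in place of vinyl on a carbonyl carbon. Both measured steps from compound 1 also replace the vinyl on the carbonyl carbon and both raise the number, yet neither brings in an aromatic ring, so they bear only loosely on compound 4. For compound 4 the expected step is a 1.1-fold higher number from compound 1 to compound 4 (0.05 log units; within the scatter), nothing beyond the scatter. Compound 4 is therefore estimated at 200 nM, with a range from 50 nM to 800 nM.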

Compound 4, solubility: 320 nM
Compound 4: the middle estimate sits 1.6-fold (0.20 log units) below what was measured, and the stated range covers the measured number.
By their numbers in this assay, from the lowest: compounds 1 and 4 (each within the scatter of the next); then compound 3; then compound 2.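

At this place on the carbonyl carbon, 4-chloropyridin-3-yl brings in the first aromatic ring, and in this assay the change from vinyl stays within the scatter (a 1.8-fold higher number from compound 1 to compound 4 (0.25 log units; within the scatter)). The same group gives a modest step from 1-chloroethyl (a 2.6-fold lower number from compound 3 to compound 4 (0.41 log units; beyond the scatter)) and a large one from 2-(dimethylamino)ethyl (a 180-fold lower number from compound 2 to compound 4 (2.24 log units; beyond the scatter)), so the large gap in this set belongs to compound 2 alone. No supporting measurement accounts for these differences.

Still open, from the compounds shown here alone, is whether a pyridin-3-yl without chlorine or a plain phenyl ring would read like compound 4. A shorter dimethylaminomethyl chain or a carboxylic acid at this place is also untested here.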